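A few compounds are considered here, and "the series" means these few. Any claim that something is new, unique, unknown or untested is made for them only; others in the source may bear on it.

Measured so far:
- compound 1 `CCc1ccc(NC(=O)Nc2cc(C)nc3ccccc23)cc1`: 16000 nM
- compound 2 `Cc1cc(NC(=O)Nc2cccc(C(N)=O)c2)c2ccccc2n1`: > 25000 nM
- compound 3 `Cc1cc(NC(=O)Nc2ccc3[nH]cnc3c2)c2ccccc2n1`: > 25000 nM

Not yet measured:
- compound 4 `Cc1cc(NC(=O)Nc2ccc(C(F)(F)F)cc2)c2ccccc2n1`

All three readings come from an ADME assay on HEK293 cells (Homo sapiens) for cytotoxicity, with a stated time of 72 h; on this read-out higher numbers stand for an effect only at larger amounts of compound and lower numbers for an effect already at smaller amounts. For the measured compounds named here, compound 1 gives 16000 nM, the only actual number so far. Compound 2 reads > 25000 nM, which is a limit of the assay and not a number. Compound 3 reads > 25000 nM, which is also a limit. Going by the values given here, the series is therefore dominated by the limit of > 25000 nM in this assay, at which 2 of the 3 values shown sit, and compound 1 is the only compound with a measured position.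

The next compound keeps the shared core of compound 1. Trifluoromethyl takes the place of ethyl on an aromatic carbon of a six-membered aromatic ring of carbon only, para to a large group (trifluoromethyl in place of ethyl on an aromatic carbon). Among the compounds with values here, no measured pair shows what a change at this place does. Within the data shown here, the only anchor is compound 1 at 16000 nM, so no step beyond the scatter is expected in this assay, and no direction is favoured. The estimated change is a 1.1-fold lower number from compound 1 to compound 4 (0.06 log units; within the scatter). For compound 4, a reading reported only as a limit remains possible. Compound 4 is estimated at 14000 nM, with an expected range from 5000 nM to 30000 nM.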

Compound 4, half-maximal effective concentration: 25000 nM
The estimate for compound 4 lay 1.8-fold (0.25 log units) below the measured number; low and high end bracket the measured number.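

In this assay compound 4 gives 25000 nM, a number and not a limit, so the series now holds a second measured position and its first readable step at this place, on an aromatic carbon of a six-membered aromatic ring of carbon only, para to a large group. Trifluoromethyl in place of ethyl gives a 1.6-fold higher number from compound 1 to compound 4 (0.19 log units; within the scatter), so this exchange, with its larger heavy-atom count, does not separate the two compounds in this read-out. The number for compound 4 carries the same figure as the limit that marks the rest of the series: the limit of > 25000 nM in this assay, at which 2 of the 4 values shown sit.

Going by these compounds, a single step within the scatter gives this position no direction, and what an amine, a carboxylic acid or a longer chain in place of ethyl would read in this assay stays open. On these data alone, whether a change on the shared core itself would move the reading, in either direction and beyond the scatter, also stays open.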